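Three Limits and a Fourth Compound Awaited

The source may hold more compounds than are shown below. What is called first, only, known or untested is meant among the compounds shown, and "the series" means these compounds.

Compound 1 `Sc1nncc2cncn12` was tested in a functional assay for inhibition, with Homo sapiens as the target; a lower number here means a stronger inhibitor, a higher number a weaker inhibitor. Here compound 1 gives > 48000 nM, which is a limit of the assay rather than a number. Compound 2 `CCCc1ncn2c(S)nncc12` carries the change propyl in place of hydrogen on an aromatic carbon relative to compound 1. In this assay compound 2 gives > 48000 nM, again a limit. The step that the two limits leave unreadable from compound 1 to compound 2 therefore cannot be read from the two values. Compound 3 `Cc1nc(C)n2c(O)nncc12` rests on a different core; how its core differs from that of compound 1 is not broken down here. In this assay compound 3 gives > 48000 nM, once more a limit.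

Compound 4 `CCCc1nnc(O)n2c(C)nc(C)c12` is not yet measured. It differs from compound 3 by propyl in place of hydrogen on an aromatic carbon. Going by the values given here, this is the same kind of change as the one from compound 1 to compound 2, but not the same: in compound 2 the propyl enters on an aromatic carbon of a five-membered aromatic ring with 2 nitrogen, two ring bonds from the ring nitrogen, whereas in compound 4 it enters on an aromatic carbon of a six-membered aromatic ring with 3 nitrogen, ortho to a fused ring, two atoms from the ring nitrogen, meta to a fused ring and para to a hydroxy group. All that the measured compounds offer is the limit of > 48000 nM in this assay, at which 3 of the 3 values shown sit. Among the compounds with values here, the only measured instance of this kind of change left compound 2 at the same limit as compound 1. Compound 4 is therefore expected to remain at that limit as well, with the step that the limit leaves unreadable from compound 3 to compound 4 an expectation only. For compound 4 the estimated value in this assay is 90000 nM, within an expected range from 30000 nM to 400000 nM.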

Compound 4, half-maximal inhibitory concentration: > 48000 nM
Compound 4 ended at the assay's limit (the forecaster's own chance of this, stated with the estimate: 80%); the middle value lies beyond the limit too.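

Going by these compounds alone, compound 4 stays at a limit of the assay, as compound 3 does, so the step between them cannot be read, any more than the one from compound 1 to compound 2. All the compounds now stand alike: the limit of > 48000 nM in this assay, at which 4 of the 4 values shown sit. The compounds shown leave open whether propyl in place of hydrogen on an aromatic carbon has any effect at all in this assay.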